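The source may hold more compounds than are shown below. What is called first, only, known or untested is meant among the compounds shown, and "the series" means these compounds.

Measured so far:
Compound 1, `Nc1scc(CN2CCN(c3ccc(OC(F)(F)F)cc3)CC2)c1C(=O)c1ccc(Cl)cc1`: -51%
Compound 2, `Nc1scc(CN2CCN(c3cc(F)cc(F)c3)CC2)c1C(=O)c1ccc(Cl)cc1`: -66%

Both compounds share a core and differ only in the aromatic group attached to an amine nitrogen in a ring. In a functional assay on CHO cells with adenosine receptor A1 (Homo sapiens) as the target, read by cAMP accumulation and immunoassay, with a stated time of 6 min, tested at 1 uM (a higher number here means a weaker effect of the compound at the concentration tested, a lower number a stronger effect), compound 1 gives -51%, while compound 2 gives -66%, the lower of the two numbers and therefore the stronger effect; the change was a number 15 percentage points lower from compound 1 to compound 2 (beyond the scatter).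

Compound 3, `Nc1scc(CN2CCN(c3ccc(F)c(Cl)c3)CC2)c1C(=O)c1ccc(Cl)cc1`, has not yet been measured. It keeps the core of compound 2 and changes the same aromatic group once more: 3-chloro-4-fluorophenyl in place of 3,5-difluorophenyl on an amine nitrogen in a ring.

Among the compounds with values here, the only measured step that bears on this place is the one from compound 1 to compound 2, where exchanging one aromatic group for another moved the number by a modest amount. The new group in compound 3 resembles the one it replaces in size and in having no donors or acceptors, so a step of similar or smaller size is expected, most likely within the scatter and with no clear direction. Compound 3 is therefore expected to give -58% in this assay, ranging from -80% to -35%, which means an estimated step of a number 8 percentage points higher from compound 2 to compound 3 (within the scatter).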

Compound 3, a percentage reported as activity, at one concentration (the size of the read-out at that concentration, not a potency): -60%
For compound 3 the middle estimate is 2 percentage points above the measured one; the range from low to high includes it.
By their numbers in this assay, from the lowest: compounds 2, 3 and 1 (each within the scatter of the next, the first and the last beyond it).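

Putting 3-chloro-4-fluorophenyl in place of 3,5-difluorophenyl on an amine nitrogen in a ring gives, in this assay, a number 6 percentage points higher from compound 2 to compound 3 (within the scatter), so at this position, swapping one halogen-bearing phenyl group for another with the same count of heavy atoms produces no readable change. Within the data shown here, putting the same group in place of 4-(trifluoromethoxy)phenyl gives a number 9 percentage points lower from compound 1 to compound 3 (within the scatter), so compound 3 cannot be told apart from either of the earlier compounds, even though those two lie beyond the scatter of each other. No measurement is available here that would explain these results.

The compounds shown all carry a halogen-bearing or fluorinated phenyl group at this position, so it remains open how a plain phenyl, a pyridine ring or a benzyl group would behave there. Each result is also a read-out at one concentration rather than a potency, so small differences among compounds of this kind may need full concentration-response curves before they can be separated.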